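Removing the aryl group from a tricyclic quinone hydantoin

The source may report more compounds than this note shows. Statements on the series, on what has been measured and on what is new or still open speak of the compounds shown alone.

Compounds 1, 2 and 3 share a core and differ only in the group carried by the aromatic ring on the ring nitrogen. Compound 1, `CCN(CC)c1ccc(N2C(=O)NC3(CSC4=C3C(=O)c3ncccc3C4=O)C2=O)cc1`, gives 730 nM in a functional assay on XF498 cells (Homo sapiens) for antiproliferative activity, read by MTT assay, with a stated time of 96 h; on this read-out higher numbers stand for weaker inhibition and lower numbers for stronger inhibition. Compound 2, `CCCc1ccc(N2C(=O)NC3(CSC4=C3C(=O)c3ncccc3C4=O)C2=O)cc1`, gives 450 nM, and compound 3, `CCCCCc1ccc(N2C(=O)NC3(CSC4=C3C(=O)c3ncccc3C4=O)C2=O)cc1`, gives 830 nM. Compound 2 has the lowest number of the three, but the step of a 1.6-fold lower number from compound 1 to compound 2 (0.21 log units; within the scatter) and the step of a 1.8-fold higher number from compound 2 to compound 3 (0.27 log units; within the scatter) are both within the scatter, as is a 1.1-fold higher number from compound 1 to compound 3 (0.06 log units; within the scatter), so the three are not distinguished.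

Compound 4, `O=C1NC(=O)C2(CSC3=C2C(=O)c2ncccc2C3=O)N1`, is not yet measured. It differs from compound 2 by hydrogen in place of 4-propylphenyl on an amide-type nitrogen in a ring. Within the data shown here, none of the measured steps bears on this change: each of them swaps one group for another on the aromatic ring, whereas here the whole 4-propylphenyl is removed, so the expectation rests on no measured step and carries a wide range. Since the three measured compounds sit within the scatter of one another, compound 4 is estimated at 1500 nM, with a range from 400 nM to 6000 nM. This estimate means a step of a 3.3-fold higher number from compound 2 to compound 4 (0.52 log units; beyond the scatter), expected to be a weaker inhibition but with low confidence.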

Compound 4, half-maximal inhibitory concentration: 3120 nM
Beside the measured number, compound 4's estimate is 2.1-fold (0.32 log units) below it; the range from low to high includes it.
By their numbers in this assay, from the lowest: compounds 2, 1 and 3 (each within the scatter of the next); then compound 4.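

In this assay, the steps among compounds 1, 2 and 3 only exchanged one group for another on the aromatic ring and all stayed within the scatter. Among these compounds, removing the whole 4-propylphenyl from the amide-type nitrogen gives a 6.9-fold higher number from compound 2 to compound 4 (0.84 log units; beyond the scatter), the first step in this set to lie beyond the scatter, so this change at this position does register, in the direction of weaker inhibition. Nothing shown here gives a reason for the step.

The compounds shown leave open whether the loss goes with the six-membered aromatic ring itself or with the absence of any group on this nitrogen, as the step removes the ring and its propyl chain together, and an unsubstituted phenyl, a benzyl or a simple methyl on the same nitrogen would separate these possibilities. They also leave open whether a group of a different kind on the aromatic ring, such as a carboxylic acid or a primary amine, would move the number beyond the scatter, as the diethylamino, propyl and pentyl groups did not.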